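This account rests on a few compounds, and the source may have more. Where it says the series, first, only, none or still open, it means among the compounds named here.

Compound 1 `CC1=C(c2ccc(F)cc2)C(c2ccc(OC[C@H](C)N3CC[C@@H](C)C3)cc2)Oc2ccc(O)cc21`: 0.4 nM
Compound 2 `CC1=C(c2cccc(C#N)c2)C(c2ccc(OC[C@H](C)N3CC[C@@H](C)C3)cc2)Oc2ccc(O)cc21`: 2.6 nM

Both values come from a functional assay on MCF7 cells (Homo sapiens) for antiproliferative activity, read by CellTiter-Glo, with a stated time of 5 days; on this read-out higher numbers stand for weaker inhibition and lower numbers for stronger inhibition. Compound 2 has the higher of the two numbers, so it is the weaker inhibitor of this pair. Compound 3 `CC1=C(c2cccc(F)c2)C(c2ccc(OC[C@H](C)N3CC[C@@H](C)C3)cc2)Oc2ccc(O)cc21` has not yet been measured. It differs from compound 2 in a single place, with fluoro in place of cyano on an aromatic carbon. In larger terms, 3-cyanophenyl becomes 3-fluorophenyl.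

Among the compounds with values here, only one measured step bears on this change: a 6.5-fold higher number from compound 1 to compound 2 (0.81 log units; beyond the scatter). That modest step, which lies beyond the scatter, came with 3-cyanophenyl in place of 4-fluorophenyl. Within the data shown here, it changed both the group and its place on the ring, and no measured compound separates the two. Compound 3 shares the fluoro group with compound 1 at 0.4 nM, but not its place, so only part of that step is expected to be recovered in this assay, towards a lower number. The expected change is a 3.3-fold lower number from compound 2 to compound 3 (0.51 log units; beyond the scatter). For compound 3 the estimated value is 0.8 nM, with an expected range from 0.25 nM to 2.5 nM.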

Compound 3, half-maximal inhibitory concentration: 1 nM
Compound 3: the middle estimate sits 1.3-fold (0.10 log units) below what was measured, within the range that was stated.
By their numbers in this assay, from the lowest: compound 1; then compound 3; then compound 2.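

Two things were tangled in the earlier step, and compound 3 begins to pull them apart in this assay. With the place on the ring held, the step of a 2.6-fold lower number from compound 2 to compound 3 (0.41 log units; beyond the scatter) shows that the group alone matters here, while the step of a 2.5-fold higher number from compound 1 to compound 3 (0.40 log units; beyond the scatter) keeps fluoro and changes only its place, going from 4-fluorophenyl to 3-fluorophenyl, so the place alone matters as well; both steps lie beyond the scatter, and together they make up the earlier 6.5-fold higher number from compound 1 to compound 2 (0.81 log units; beyond the scatter) with neither part accounting for all of it. Nothing measured here tells why either the group or the place changes the number.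

The compounds shown leave open whether 4-cyanophenyl would sit as far above 4-fluorophenyl as 3-cyanophenyl sits above 3-fluorophenyl, which is what would show whether the effects of group and place simply add. They also leave open how a chloro group, a methoxy group or an amine would read at either place on this ring, and how the plain phenyl ring without any such group compares.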